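Removing a chlorine from a quinone: one step as guide

A few compounds are considered here, and "the series" means these few. Any claim that something is new, unique, unknown or untested is made for them only; others in the source may bear on it.

Compound 1 `Cc1cc(Cl)c2c(c1O)C(=O)C=CC2=O` gives 10100 nM.
Compound 2 `CC(=O)Oc1cc(OC(C)=O)c2c(OC(C)=O)cc(C)c(Cl)c2c1OC(C)=O` gives 52900 nM.
Compound 3 `CC(=O)Oc1cc(OC(C)=O)c2c(OC(C)=O)cc(C)cc2c1OC(C)=O` gives 22400 nM.

These numbers come from a functional assay on HeLa cells (Homo sapiens) for cytotoxicity, read by XTT assay, with a stated time of 24 h; on this read-out lower numbers stand for stronger inhibition and higher numbers for weaker inhibition. Compound 1 and compound 2 have different cores; the difference between the two cores is not broken down here. Compound 2 and compound 3 differ in one place, (hydrogen in place of chloro on an aromatic carbon), and the step was a 2.4-fold lower number from compound 2 to compound 3 (0.37 log units; beyond the scatter). Compound 4 `Cc1ccc2c(c1O)C(=O)C=CC2=O` is not yet measured; it differs from compound 1 by hydrogen in place of chloro on an aromatic carbon. The surroundings differ: in compound 1 the site is meta to a methyl group and para to a hydroxy group, while in compound 2 it is ortho to a methyl group and para to an acetoxy group, so this is the same kind of change, not the same change. Because a 2.4-fold lower number from compound 2 to compound 3 (0.37 log units; beyond the scatter) was seen, a similar step is expected for compound 4: a 2.2-fold lower number from compound 1 to compound 4 (0.35 log units; beyond the scatter). Compound 4 is therefore estimated at 4500 nM, likely between 1500 nM and 14000 nM.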

Compound 4, half-maximal inhibitory concentration: 16400 nM
Estimate against measurement, compound 4: 3.6-fold (0.56 log units) below, and the stated range ends below it.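

In this assay putting hydrogen in place of chloro on the core of compound 1 gives a 1.6-fold higher number from compound 1 to compound 4 (0.21 log units; within the scatter) and this step stays within the scatter, so the two compounds cannot be told apart here. Within the data shown here, with only two pairs, this does not show why the cores part ways, nor how the change would behave on any third core. What it does show is that the step on one core did not carry over to the other: the same change on two cores in this assay, a 2.4-fold lower number (0.37 log units; beyond the scatter) from compound 2 to compound 3 and a 1.6-fold higher number (0.21 log units; within the scatter) from compound 1 to compound 4, 3.8-fold (0.58 log units) apart, beyond the scatter of two such steps

Only chloro and hydrogen are shown at these sites. From the compounds shown here alone, whether a bromo group, a methoxy group or an amine there would follow either core remains open.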